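A few compounds are considered here, and "the series" means these few. Any claim that something is new, unique, unknown or untested is made for them only; others in the source may bear on it.

The measured compounds:

Compound 1, `CCO/N=C/Nc1cc(Cl)c(OC(C)C)c(Cl)c1` — a physicochemical assay for lipophilicity, measured as octanol-water partition; on this read-out higher numbers stand for higher lipophilicity and lower numbers for lower lipophilicity: 4.4
Compound 2, `CC#CCOc1c(Cl)cc(N/C=N/OCC)cc1Cl` — this assay: 4
Compound 3, `C#CCc1c(Cl)cc(N/C=N/OC(C)CC)cc1Cl` — this assay: 4.2

Compound 3 sits between the other two on the numbers, and its value lies within the usual scatter of both compound 1 and compound 2, so no ordering among the three can be drawn from it. Going by the values given here, the only step beyond the scatter is a number 0.40 log units lower from compound 1 to compound 2 (beyond the scatter), a change on the oxygen of the aromatic ring, not on the oxygen that carries the change considered here.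

Compound 4, `C#CCc1c(Cl)cc(N/C=N/Oc2ccc(C)cc2)cc1Cl`, has not yet been measured in this assay. It differs from compound 3 in one place: 4-methylphenyl in place of sec-butyl on an oxygen. Among the compounds with values here, no measured pair covers an alkyl-to-aryl exchange on this oxygen, so the measured steps give no direct guide; the one step beyond the scatter, from compound 1 to compound 2, concerns a different position and a different kind of exchange. Given that the entering group is larger in heavy-atom count than the group it replaces, compound 4 is expected to read 4.7, with a range from 4.2 to 5.2. The step this estimate implies is expected to be a number 0.50 log units higher from compound 3 to compound 4 (beyond the scatter), an increase beyond the scatter, though with considerable uncertainty.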

Compound 4, partition coefficient: 4.8
Compound 4: the middle estimate sits 0.10 log units below what was measured; low and high end bracket the measured number.
By their numbers in this assay, from the lowest: compounds 2, 3 and 1 (each within the scatter of the next, the first and the last beyond it); then compound 4.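

In this assay, replacing sec-butyl with 4-methylphenyl on an oxygen whose other neighbours are a double-bonded nitrogen gives a number 0.60 log units higher from compound 3 to compound 4 (beyond the scatter) and is the only step shown at this position. Going by these compounds alone, until now, the only step beyond the scatter lay on the oxygen on an aromatic ring, so this result shows that the read-out also responds to an exchange on the oxygen bound to nitrogen, here from an alkyl group to an aryl group. The exchange raises the heavy-atom count and adds one six-membered aromatic ring of carbon only, while both groups have 0 hydrogen-bond donors, 0 hydrogen-bond acceptors and no net charge, and nothing available explains the size of this step.

Going by these compounds, a single step cannot separate the ring from the higher carbon count, so it remains open how a plain phenyl, a pyridyl ring or a straight heptyl chain on this oxygen would read. On these data alone, it is also open whether the same exchange would give a similar step on the core of compound 1 or the core of compound 2.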